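This account rests on a few compounds, and the source may have more. Where it says the series, first, only, none or still open, it means among the compounds named here.

Working notes on the series. Compound 1 `COc1cc(-c2cc(/C=C/C(=O)c3ccc(N)cc3)[nH]n2)cc(OC)c1OC` and compound 2 `COc1ccc(-c2cc(/C=C/C(=O)c3ccc(N)cc3)[nH]n2)cc1OC` share one core; compound 3 `COc1cc(C(=O)/C=C/c2cc(-c3cc(OC)c(OC)c(OC)c3)n[nH]2)cc(OC)c1OC` is built on a different core, and the difference between the two cores is not broken down here. Compound 4 `COc1ccc(-c2cc(/C=C/C(=O)c3cc(OC)c(OC)c(OC)c3)[nH]n2)cc1OC` has not yet been measured.

In a functional assay on HOP-92 cells (Homo sapiens) for inhibition, read by sulforhodamine B assay, with a stated time of 48 h (a lower number here means that less compound is tolerated, a higher number that more compound is tolerated), compound 1 gives > 100000 nM, which is a limit of the assay and not a number. In this assay compound 2 gives 63900 nM. The step of an at least 1.5-fold lower number from compound 1 to compound 2 (0.19 log units; that floor lies within the scatter) comes from the change (hydrogen in place of methoxy on an aromatic carbon); its size is uncertain because compound 1 sits at the limit of > 100000 nM in this assay, at which 1 of the 3 values shown sits. In this assay compound 3 gives 5540 nM, the lowest of the two numbers shown.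

The change from compound 3 to compound 4 is hydrogen in place of methoxy on an aromatic carbon, the same change as from compound 1 to compound 2, so it occurs twice among these compounds. Among the compounds with values here, since the only measured instance, an at least 1.5-fold lower number from compound 1 to compound 2 (0.19 log units; that floor lies within the scatter), has a floor within the scatter, no clear direction is set by it. The expected step is therefore small, a 1.2-fold lower number from compound 3 to compound 4 (0.09 log units; within the scatter), resting on compound 3 at 5540 nM. Compound 4 is estimated at 4500 nM in this assay, expected between 1500 nM and 15000 nM.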

Compound 4, concentration lethal to 50% of the cells: 26600 nM
Estimate against measurement, compound 4: 5.9-fold (0.77 log units) below, and the stated range ends below it.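

In this assay, hydrogen in place of methoxy gives a 4.8-fold higher number from compound 3 to compound 4 (0.68 log units; beyond the scatter), and this step does not agree with the one seen earlier on the other core: the same change on two cores in this assay, an at least 1.5-fold lower number (0.19 log units; that floor lies within the scatter) from compound 1 to compound 2 and a 4.8-fold higher number (0.68 log units; beyond the scatter) from compound 3 to compound 4, at least 7.5-fold (0.87 log units) apart, beyond the scatter of two such steps The change therefore does not carry from one core to the other as a single step of fixed size, so a step read on the core of compound 1 gives no safe forecast for the core of compound 3 in this series. These two pairs do not show which difference between the cores is responsible, nor do they set a rule for any further core, and with compound 1 at a limit of the assay the earlier step has only a floor: the limit of > 100000 nM in this assay, at which 1 of the 4 values shown sits.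

The compounds shown leave open whether the same methoxy position would behave alike on both cores with a hydroxy group or a chlorine atom in place of hydrogen. They also leave open how the change would run on a core carrying a carboxylic acid where compound 1 and compound 2 carry their amine.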